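A methyl to chloro swap in a growth assay

This account rests on a few compounds, and the source may have more. Where it says the series, first, only, none or still open, it means among the compounds named here.

In a functional assay on NCI-H226 cells (Homo sapiens) for inhibition (on this read-out higher numbers stand for weaker inhibition of growth and lower numbers for stronger inhibition of growth), the measured compounds are these
Compound 1 `Clc1ccc(-c2nn(-c3ccccc3)c3ncncc23)cc1` gives 18000 nM
Compound 2 `Cc1ccc(-c2nn(-c3ccc4ccccc4n3)c3ncncc23)cc1` gives 29000 nM

In this assay compound 2 at 29000 nM lies within the usual scatter of compound 1 at 18000 nM and the two cannot be told apart. They differ in more than one place, so no single change can be read from the pair.

Compound 3 `Clc1ccc(-c2nn(-c3ccc4ccccc4n3)c3ncncc23)cc1` has not yet been measured. It differs from compound 2 in one place, with chloro in place of methyl on an aromatic carbon, which turns 4-methylphenyl into 4-chlorophenyl. Among the measured compounds shown here, no measured pair shows this change on its own, so the data do not size it directly. Compound 1 carries the same 4-chlorophenyl and gives 18000 nM with a different group elsewhere in the molecule. In this assay no shift beyond the scatter is expected, and the estimated step is a 1.2-fold lower number from compound 2 to compound 3 (0.06 log units; within the scatter) in size. Compound 3 is expected at 25000 nM (estimated range 10000 nM to 60000 nM).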

Compound 3, concentration for 50% growth inhibition: 39000 nM
The estimate for compound 3 lay 1.6-fold (0.19 log units) below the measured number, and the stated range covers the measured number.
By their numbers in this assay, from the lowest: compounds 1, 2 and 3 (each within the scatter of the next, the first and the last beyond it).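

In this assay, the change from 4-methylphenyl to 4-chlorophenyl now has a size of its own, with a step of a 1.3-fold higher number from compound 2 to compound 3 (0.13 log units; within the scatter) on this read-out. At this place, on an aromatic carbon of a six-membered aromatic ring of carbon only and para to a large group, methyl and chloro cannot be told apart in this assay, something compound 1 and compound 2 could not show because they differ in more than one place. The finding rests on this single pair, and no measurement given here bears on why the two groups read alike.

The compounds shown leave open whether a group of another kind at this place, such as an amine, a methoxy group or a carboxylic acid, would read apart from methyl and chloro. They also leave open whether the same swap would give a step of similar size with the group of compound 1 elsewhere in the molecule, since the methyl partner of compound 1 is not among them.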